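The source may hold more compounds than are shown below. What is called first, only, known or untested is meant among the compounds shown, and "the series" means these compounds.

Measured so far:
compound 1, `COc1cc([C@H]2C[C@]2(CO)C(=O)Nc2ccccc2Cl)cc(OC)c1OC` — 40200 nM
compound 2, `COc1cc([C@@H]2C[C@@]2(CO)C(=O)Nc2ccccc2)cc(OC)c1OC` — 76800 nM

Of the compounds shown here, two sharing a common core have been tested in a functional assay on SW480 cells (Homo sapiens) for cytotoxicity, read by MTT assay, with a stated time of 48 h; on this read-out lower numbers stand for stronger inhibition and higher numbers for weaker inhibition. Compound 1 gives 40200 nM and compound 2 gives 76800 nM. For the measured compounds named here, compound 2 therefore has the highest of the two numbers, with compound 1 as its only neighbour; the gap between the two falls within the usual scatter of such measurements, so nothing can be said about an order between them.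

The step under consideration leads from compound 2 to compound 3, `COc1cc([C@@H]2C[C@@]2(CO)C(=O)Nc2ccccc2Cl)cc(OC)c1OC`, which has not yet been measured in this assay. The structural change is chloro in place of hydrogen on an aromatic carbon. Going by the values given here, no step between measured compounds is available to calibrate what this change does. With the two measured values lying within the scatter of each other, no step beyond the scatter is expected in this assay in either direction for compound 3. The estimate for compound 3 in this assay is therefore 55000 nM, with a range from 22000 nM to 130000 nM. This estimate corresponds to an expected step of a 1.4-fold lower number from compound 2 to compound 3 (0.14 log units; within the scatter).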

Compound 3, half-maximal inhibitory concentration: 10700 nM
Compound 3: the middle estimate sits 5.1-fold (0.71 log units) above what was measured; measured number outside the range, below it.
By their numbers in this assay, from the lowest: compound 3; then compounds 1 and 2 (each within the scatter of the next).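

In this assay, for the compounds shown here, chloro in place of hydrogen on an aromatic carbon, ortho to a large group, now has a measured size for the first time: a 7.2-fold lower number from compound 2 to compound 3 (0.86 log units; beyond the scatter), a modest change beyond the scatter. The earlier pair could not show this, as compounds 1 and 2 lay within the scatter of each other and differ in more than one place. The result also shows that configuration counts among the chlorinated compounds, with a 3.8-fold lower number from compound 1 to compound 3 (0.57 log units; beyond the scatter), again modest and beyond the scatter, and this step can be put down to configuration alone, on this ground: the fact that compounds 1 and 3 differ only in the configuration as drawn

The effect of chloro is known only in the configuration of compounds 2 and 3, so what it does in the configuration of compound 1 remains open, as the compounds shown include no hydrogen-bearing partner of compound 1. Also open, going by these compounds, is whether a bromo, methyl or methoxy group at the same place would lower the number as chloro does, and whether a carboxylic acid in place of the hydroxymethyl group would keep the number of compound 3.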